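A few compounds are considered here, and "the series" means these few. Any claim that something is new, unique, unknown or untested is made for them only; others in the source may bear on it.

Within the data shown here, in a functional assay on LoVo cells (Homo sapiens) for inhibition, read by colorimetric assay and MTT assay, with a stated time of 72 h (a lower number here means a stronger inhibitor, a higher number a weaker inhibitor), compound 1 `C=CCCCCOc1ccccc1-c1cnc(OCCC=C)n1C` gives 12000 nM, the lowest of the two numbers measured so far, which makes it the stronger inhibitor of the pair. Compound 2 `C=CCCCCOc1ccc(OC)cc1-c1cnc(OCCC=C)n1C` gives 33000 nM. Among the measured compounds shown here, its methoxy in place of hydrogen on an aromatic carbon produces a 2.8-fold higher number from compound 1 to compound 2 (0.44 log units; beyond the scatter), a modest change but the only measured step available here.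

The open question is compound 3 `C=CCCCCOc1cc(F)ccc1-c1cnc(OCCC=C)n1C`. Its difference from compound 1 is fluoro in place of hydrogen on an aromatic carbon. Put simply, a fluoro replaces hydrogen on an aromatic carbon, meta to the (hex-5-en-1-yl)oxy group and para to a large group.

The methoxy step bears on this only loosely, since it also swaps a hydrogen on an aromatic carbon but brings in a different group. One step cannot establish a trend, yet its modest size, a 2.8-fold higher number from compound 1 to compound 2 (0.44 log units; beyond the scatter), argues against expecting a large change. The expected result is a 1.3-fold higher number from compound 1 to compound 3 (0.10 log units; within the scatter), a small rise that stays within the scatter. For compound 3 the estimated value is 15000 nM, with an expected range from 7000 nM to 32000 nM.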

Compound 3, half-maximal inhibitory concentration: 45000 nM
Compound 3: the middle estimate sits 3.0-fold (0.48 log units) below what was measured; measured number outside the range, above it.
By their numbers in this assay, from the lowest: compound 1; then compounds 2 and 3 (each within the scatter of the next).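

In this assay, adding a single fluoro on the aromatic ring, meta to a (hex-5-en-1-yl)oxy group and para to a large group, gives a 3.8-fold higher number from compound 1 to compound 3 (0.57 log units; beyond the scatter) and so weakens inhibition. This shows that even one added heavy atom, with no ring, no charge and no hydrogen-bond donors or acceptors, is enough at this position to move the result beyond the usual variation between repeat measurements. Alongside the methoxy change, which gives a 2.8-fold higher number from compound 1 to compound 2 (0.44 log units; beyond the scatter), it also leaves compound 1, with hydrogen at both changed places, as the strongest inhibitor of the three, while nothing available explains why the fluoro has this effect.

With only one substituent shown at this position, the results cannot say whether the loss is particular to fluoro or would also appear with a chloro, a hydroxyl, an amine or a nitrile in its place. They also leave open whether the same fluoro would raise the number at the other carbons of this ring, or whether any group on this ring could bring the number below that of compound 1.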